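Methylsulfanyl to methylsulfonyl on the shared core

The source may hold more compounds than are shown below. What is called first, only, known or untested is meant among the compounds shown, and "the series" means these compounds.

Three compounds on the shared core have numbers in a functional assay on HEK293 cells for antagonist activity at transient receptor potential cation channel subfamily V member 1 (Rattus norvegicus), read by calcium flux; on this read-out lower numbers stand for stronger inhibition and higher numbers for weaker inhibition. Compound 1 `FC(F)(F)c1ccc(Nc2ncnc3sc(Nc4c(Cl)cccc4Cl)nc23)cc1` gives 3 nM, compound 2 `Cc1ccc(Nc2ncnc3sc(Nc4c(Cl)cccc4Cl)nc23)cc1` gives 32 nM, and compound 3 `CSc1ccc(Nc2ncnc3sc(Nc4c(Cl)cccc4Cl)nc23)cc1` gives 12 nM. Compound 3 thus holds the second highest of the three numbers: a 2.7-fold lower number from compound 2 to compound 3 (0.43 log units; beyond the scatter) and a 4.0-fold higher number from compound 1 to compound 3 (0.60 log units; beyond the scatter), both beyond the scatter.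

Compound 4 `CS(=O)(=O)c1ccc(Nc2ncnc3sc(Nc4c(Cl)cccc4Cl)nc23)cc1` differs from compound 3 in one place: methylsulfonyl in place of methylsulfanyl on an aromatic carbon.

Among the compounds with values here, no measured step swaps methylsulfanyl for methylsulfonyl, so the bearing steps are the other swaps at this same aromatic carbon: an 11-fold higher number from compound 1 to compound 2 (1.03 log units; beyond the scatter), a 4.0-fold higher number from compound 1 to compound 3 (0.60 log units; beyond the scatter) and a 2.7-fold lower number from compound 2 to compound 3 (0.43 log units; beyond the scatter). Three different groups there gave three numbers spread over a modest-to-large range, so a step of modest size is expected for compound 4 as well, with the direction uncertain; a modest rise of the number is taken as the estimate, a 3.3-fold higher number from compound 3 to compound 4 (0.52 log units; beyond the scatter).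

Compound 4 is therefore expected to give about 40 nM in this assay, with a range from 10 nM to 160 nM.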

Compound 4, half-maximal inhibitory concentration: 3 nM
Estimate against measurement, compound 4: 13-fold (1.12 log units) above, and the stated range ends above it.
By their numbers in this assay, from the lowest: compounds 1 and 4 (each within the scatter of the next); then compound 3; then compound 2.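

Methylsulfonyl in place of methylsulfanyl on this aromatic carbon, para to a large group, gives stronger inhibition, with a 4.0-fold lower number from compound 3 to compound 4 (0.60 log units; beyond the scatter). Set against methyl, the same group gives an 11-fold lower number from compound 2 to compound 4 (1.03 log units; beyond the scatter), while against trifluoromethyl it gives no change at the digits printed from compound 1 to compound 4 (within the scatter), so at this position a second group now matches trifluoromethyl, which the earlier compounds did not show. Nothing at hand explains why the two sulfur-bearing groups differ at this carbon.

From the compounds shown here alone, whether other groups at this carbon, such as a nitrile, a sulfonamide or a carboxylic acid, or a longer chain on the sulfonyl such as ethylsulfonyl, would keep the number this low remains open. Also open, going by these compounds, is whether methylsulfonyl would hold up with a change elsewhere on the shared core.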